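The compounds below may be only part of what the source reports. "The series", "measured", "known", "first", "only" and "open" are said of these compounds alone.

Compound 1 `Nc1nc(N)c2cc(CSC(=S)N3CCN(c4ccccc4)CC3)ccc2n1`: 2950 nM
Compound 2 `Cc1ccccc1N1CCN(C(=S)SCc2ccc3nc(N)nc(N)c3c2)CC1`: 4230 nM
Compound 3 `Nc1nc(N)c2cc(CSC(=S)N3CCN(c4ccccc4Cl)CC3)ccc2n1`: 3190 nM

All three values come from a functional assay on MCF7 cells (Homo sapiens) for antiproliferative activity, read by MTT assay, with a stated time of 72 h; on this read-out higher numbers stand for weaker inhibition and lower numbers for stronger inhibition. Compound 3 stands close to both of the others, with a 1.1-fold higher number from compound 1 to compound 3 (0.03 log units; within the scatter) and a 1.3-fold lower number from compound 2 to compound 3 (0.12 log units; within the scatter). Compound 4 `Nc1nc(N)c2cc(CSC(=S)N3CCN(c4ccc(Cl)c(Cl)c4)CC3)ccc2n1` has not been measured. It differs from compound 3 by 3,4-dichlorophenyl in place of 2-chlorophenyl on an amine nitrogen in a ring, with 3,4-dichlorophenyl in place of 2-chlorophenyl on an amine nitrogen in a ring.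

The nearest evidence is the step that adds chloro on an aromatic carbon, shown above for compound 3, and the methyl step, a 1.4-fold higher number from compound 1 to compound 2 (0.16 log units; within the scatter). Neither leaves the scatter, so no step beyond the scatter is expected in this assay, in either direction. However, no measured compound carries 3,4-dichlorophenyl, so the range stays wide.

For compound 4 the estimated value is 3000 nM, with an expected range from 1300 nM to 6500 nM. This estimate means an expected 1.1-fold lower number from compound 3 to compound 4 (0.03 log units; within the scatter).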

Compound 4, half-maximal inhibitory concentration: 2370 nM
Beside the measured number, compound 4's estimate is 1.3-fold (0.10 log units) above it, within the range that was stated.
By their numbers in this assay, from the lowest: compounds 4, 1, 3 and 2 (each within the scatter of the next).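

In this assay, 3,4-dichlorophenyl on the amine nitrogen in the ring stays within the scatter of all three earlier groups: 2-chlorophenyl (a 1.3-fold lower number from compound 3 to compound 4 (0.13 log units; within the scatter)), 2-methylphenyl (a 1.8-fold lower number from compound 2 to compound 4 (0.25 log units; within the scatter)) and phenyl (a 1.2-fold lower number from compound 1 to compound 4 (0.10 log units; within the scatter)). Across these four compounds, then, a second chlorine on the phenyl ring gives no step that can be told from repeat scatter. Nothing measured here explains these small steps.

As far as these compounds go, what a carboxylic acid or an amine on the phenyl ring would do stays open, as does a plain alkyl chain in place of that ring.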